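The source may report more compounds than this note shows. Statements on the series, on what has been measured and on what is new or still open speak of the compounds shown alone.

Measured so far:
Compound 1 `CCc1nn(C)c(CO/N=C/c2c(C)nn(C)c2Oc2ccccc2Cl)c1Cl` — in a functional assay on SMMC-7721 cells (Homo sapiens) for inhibition, read by MTT assay, with a stated time of 72 h, tested at 25 uM (on this read-out lower numbers stand for less inhibition and higher numbers for more inhibition at the one concentration tested (going by the name of the read-out)), compound 1 gives < 80%, which is a limit of the assay and not a number.
Compound 2 `Cc1nn(C)c(Oc2ccc(Cl)cc2)c1/C=N\OCc1c(Cl)c(-c2ccc(Cl)cc2)nn1C` — in this assay compound 2 gives 80%.

Both compounds share the same oxime ether core, each carrying a phenoxy ring with a single chloro substituent, and both were tested at one concentration. Compound 1 stands at a limit: its result is one of the two values shown, and it sits at the cutoff described by the limit of < 80% in this assay, at which 1 of the 2 values shown sits, so only a ceiling is known for it, not a figure. Compound 2 gives a numerical value at that same level. Going by the values given here, no pair of measured compounds differs in only one place, so no measured step exists to lean on.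

Compound 3 `CCc1nn(C)c(CO/N=C/c2c(C)nn(C)c2Oc2ccccc2C)c1Cl` is the next compound to be measured. It differs from compound 1 by methyl in place of chloro on an aromatic carbon. Methyl and chloro are each a single heavy atom and neither adds a donor or an acceptor, so in this assay no step beyond the scatter is expected; the expected step is a step that the limit leaves unreadable from compound 1 to compound 3. On that basis compound 3 is estimated at 50%, within a range from 20% to 79%.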

Compound 3, a percentage reported as inhibition, at one concentration (the size of the read-out at that concentration, not a potency): < 80%
Compound 3: no number, only a limit; the forecaster's own chance of this, stated with the estimate: 70%; the middle value lies beyond the limit too.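

In this assay, compound 1 and compound 3 each give a limit of the assay and not a number, so no step can be read between them: the limit of < 80% in this assay, at which 2 of the 3 values shown sit.

The compounds shown leave open whether methyl in place of chloro on the aromatic carbon changes the inhibition at all, and in which direction.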